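The source may hold more compounds than are shown below. What is called first, only, known or untested is meant among the compounds shown, and "the series" means these compounds.

Measured compounds: compound 1 `Cc1cc(C(=O)Nc2ccccc2)nn1Cc1cc(Cl)ccc1OCc1ccccc1`, in an in vitro ADME assay on microsomes from liver (Rattus norvegicus) for metabolic stability (a lower number here means slower removal, a higher number faster removal of the compound), compound 1 gives 12 mL.min-1.g-1; compound 2 `Cc1cc(C(=O)NCc2ccccn2)nn1Cc1cc(Cl)ccc1OCc1ccccc1`, compound 2 gives 30 mL.min-1.g-1; compound 3 `Cc1cc(NC(=O)c2ccccc2)nn1Cc1cc(Cl)ccc1OCc1ccccc1`, compound 3 gives 7.3 mL.min-1.g-1.

Compound 3 sits at the low end of these three numbers: the step of a 1.6-fold lower number from compound 1 to compound 3 (0.22 log units; within the scatter) is within the scatter, while the step of a 4.1-fold lower number from compound 2 to compound 3 (0.61 log units; beyond the scatter) is beyond it. Compound 4 `Cc1cc(NC(=O)OCc2ccccn2)nn1Cc1cc(Cl)ccc1OCc1ccccc1` differs from compound 3 in one place: (pyridin-2-yl)methoxy in place of phenyl on a carbonyl carbon. Within the data shown here, the only measured step of a related kind is a 2.5-fold higher number from compound 1 to compound 2 (0.40 log units; beyond the scatter), where a (pyridin-2-yl)methyl group entered on an amide-type nitrogen and the number rose modestly. A modest rise in this assay is therefore expected for compound 4, a 2.5-fold higher number from compound 3 to compound 4 (0.39 log units; beyond the scatter). Compound 4 is estimated at 18 mL.min-1.g-1, with a range of 8 mL.min-1.g-1 to 40 mL.min-1.g-1.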

Compound 4, intrinsic clearance in microsomes: 8.4 mL.min-1.g-1
Compound 4: the middle estimate sits 2.1-fold (0.33 log units) above what was measured; measured number inside the range.
By their numbers in this assay, from the lowest: compounds 3, 4 and 1 (each within the scatter of the next); then compound 2.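

In this assay, (pyridin-2-yl)methoxy on the carbonyl carbon leaves the number level with phenyl (a 1.2-fold higher number from compound 3 to compound 4 (0.06 log units; within the scatter)), so the rise seen when a (pyridin-2-yl)methyl group entered on the amide-type nitrogen did not carry over to this position. The (((pyridin-2-yl)methoxy)carbonyl)amino group separates clearly from ((pyridin-2-yl)methyl)carbamoyl (a 3.6-fold lower number from compound 2 to compound 4 (0.55 log units; beyond the scatter)) but not from phenylcarbamoyl (a 1.4-fold lower number from compound 1 to compound 4 (0.15 log units; within the scatter)), so a pyridin-2-yl ring does not by itself go with the high number. Nothing available explains these results. As far as these compounds go, whether an amine, a carboxylic acid or a longer chain on this carbonyl carbon would keep the number this low remains open.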